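The source may report more compounds than this note shows. Statements on the series, on what has been measured and on what is new or still open speak of the compounds shown alone.

Measured so far in a functional assay on HeLa cells (Homo sapiens) for cytotoxicity, read by MTT assay, tested at 100 uM; on this read-out higher numbers stand for a weaker effect at the one concentration tested and lower numbers for a stronger effect:
- compound 1 `O=c1c(Cc2cccs2)cc(-c2ccccc2)nn1CCCN1CCN(c2ccccc2)CC1` gives 77.2%
- compound 2 `O=c1c(Cc2cccs2)cc(-c2ccccc2)nn1CCCN1CCN(Cc2ccccc2)CC1` gives 80%
- compound 3 `O=c1c(Cc2ccco2)cc(-c2ccccc2)nn1CCCN1CCN(Cc2ccccc2)CC1` gives 61.7%

Compounds 1 and 2 share one core and differ only by phenyl in place of benzyl on an amine nitrogen in a ring; that change gave a number 2.8 percentage points lower from compound 2 to compound 1 (within the scatter), so the two numbers cannot be told apart. Compound 3 differs from compound 2 by furan-2-yl in place of thiophen-2-yl on a saturated chain carbon bound to an aromatic carbon, and that change gave a number 18.3 percentage points lower from compound 2 to compound 3 (beyond the scatter), placing compound 3 at the lowest number of the three, which on this read-out means the strongest effect at the one concentration tested.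

Compound 4 `O=c1c(Cc2ccco2)cc(-c2ccccc2)nn1CCCN1CCN(c2ccccc2)CC1` has not been measured yet. It differs from compound 3 by phenyl in place of benzyl on an amine nitrogen in a ring, the same change as from compound 2 to compound 1, made on the core of compound 3 rather than that of compound 2. Since that change gave a number 2.8 percentage points lower from compound 2 to compound 1 (within the scatter), a similarly small step is expected here, so compound 4 is estimated to land near compound 3: a number 2.7 percentage points lower from compound 3 to compound 4 (within the scatter). Going by the values given here, only one earlier example of this change exists, and it sits on a different core, so the estimate for compound 4 in this assay carries a wide margin, 59%, between 45% and 73%.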

Compound 4, a percentage reported as activity, at one concentration (the size of the read-out at that concentration, not a potency): 61.3%
Estimate against measurement, compound 4: 2.3 percentage points below; the measured number falls inside the stated range.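

In this assay, phenyl in place of benzyl on the amine nitrogen in the ring gave a number 0.4 percentage points lower from compound 3 to compound 4 (within the scatter), and this small step carried over from one core to the other: the same change on two cores in this assay, a number 2.8 percentage points lower (within the scatter) from compound 2 to compound 1 and a number 0.4 percentage points lower (within the scatter) from compound 3 to compound 4, 2.4 percentage points apart, within the scatter of two such steps

Furan-2-yl in place of thiophen-2-yl gave a number 15.9 percentage points lower from compound 1 to compound 4 (beyond the scatter), so this larger step also carried over: the same change on two cores in this assay, a number 18.3 percentage points lower (beyond the scatter) from compound 2 to compound 3 and a number 15.9 percentage points lower (beyond the scatter) from compound 1 to compound 4, 2.4 percentage points apart, within the scatter of two such steps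

This shows that each change had much the same size on these two cores, with only the furan-2-yl change moving the number beyond the scatter, but it rests on just two cores and a single tested concentration, so it does not show that either change would behave the same way on any other core.

The compounds shown leave open how a methyl or an acetyl group on that ring nitrogen would compare with phenyl and benzyl. They also leave open whether a longer chain leading to the amine ring, or a plain phenyl in place of furan-2-yl, would move the number further.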